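Swapping the aryl-bound diamine ring system in a chemokine receptor blocker

The source may hold more compounds than are shown below. What is called first, only, known or untested is meant among the compounds shown, and "the series" means these compounds.

Of the compounds shown here, three have been measured in a functional assay on CCRF-CEM cells for antagonist activity at C-X-C chemokine receptor type 4 (Homo sapiens), read by calcium flux, with stated times of 25 min and 90 s; a lower number here means a stronger inhibitor, a higher number a weaker inhibitor. Compound 1 `c1cnc2c(c1)CCC[C@@H]2N(CC1CC1)C[C@H]1Cc2c(cccc2N2CCNCC2)CN1` gives 26.7 nM. Compound 2 `CN(C[C@H]1Cc2c(cccc2N2C[C@@H]3C[C@H]2CN3)CN1)[C@H]1CCCc2cccnc21` gives 146 nM, and compound 3 `c1cnc2c(c1)CCC[C@@H]2N(CC1CCCCC1)C[C@H]1Cc2c(cccc2N2CCNCC2)CN1` gives 715 nM. Compound 2 therefore stands second highest of the three numbers: its nearest neighbour is compound 3, which lies beyond the scatter above it, and compound 1 lies beyond the scatter below it.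

Compound 4 `CN(C[C@H]1Cc2c(cccc2N2CCN3CCC[C@@H]3C2)CN1)[C@H]1CCCc2cccnc21` has not yet been measured. It differs from compound 2 only on an aromatic carbon of the shared core: a group of 9 heavy atoms (7 carbon, 2 nitrogen; one five-membered non-aromatic ring with 1 hetero atom, one six-membered non-aromatic ring with 2 hetero atoms) in place of a group of 7 heavy atoms (5 carbon, 2 nitrogen; 2 five-membered non-aromatic rings with 1 hetero atom each), on an aromatic carbon.

Among the measured compounds shown here, the one measured single-point step, a 27-fold higher number from compound 1 to compound 3 (1.43 log units; beyond the scatter), concerns the group on the saturated chain carbon bound to the amine nitrogen, a different part of the molecule, so it does not bear on the present change. Compound 1 and compound 2 differ in more than one place, so their values show only that the two aryl-bound diamine rings are not equivalent. For the measured compounds named here, with no step on this position to lean on, only a modest shift is expected, and the direction cannot be read from the data; the estimated step is a 1.4-fold higher number from compound 2 to compound 4 (0.14 log units; within the scatter).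

Compound 4 is thus expected to give about 200 nM in this assay, within a range from 60 nM to 700 nM.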

Compound 4, half-maximal inhibitory concentration: 3.59 nM
Beside the measured number, compound 4's estimate is 56-fold (1.75 log units) above it; the whole stated range lies above it.
By their numbers in this assay, from the lowest: compound 4; then compound 1; then compound 2; then compound 3.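

In this assay, the aromatic carbon of the shared core proves to be a highly sensitive position, since exchanging one diamine ring system for another there gives a 41-fold lower number from compound 2 to compound 4 (1.61 log units; beyond the scatter). This single change alters several features at once: the group that leaves has 7 heavy atoms, 1 hydrogen-bond donor and 2 defined stereocentres, while the group that enters has 9 heavy atoms, 0 hydrogen-bond donors and 1 defined stereocentre. No measurement shown here accounts for the large step, so it remains an observation without an established explanation.

The compounds shown leave open which of these differences matters, and a piperazine ring with a methyl group on its free nitrogen or a morpholine ring on the same aromatic carbon would help to separate ring size from the presence of a hydrogen-bond donor. They also leave open whether the opposite configuration at the single stereocentre of the entering group would perform as well, and whether the step would be of similar size with the cyclopropyl group of compound 1 on the chain.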